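A few compounds are considered here, and "the series" means these few. Any claim that something is new, unique, unknown or untested is made for them only; others in the source may bear on it.

Going by the values given here, in a functional assay on MOLT-4F cells (Homo sapiens) for antiproliferative activity (on this read-out lower numbers stand for stronger inhibition of growth and higher numbers for weaker inhibition of growth), compound 2 `COCCCCCCCCCCCCCCC/C=C1\CC(CO)(COC(=O)C(C)(C)C)OC1=O` gives 0.498 ug/mL, the lower of the two numbers so far, while compound 1 `COCCCCCCCCCCCCCCC/C=C1/CC(CO)(COC(=O)C(C)(C)C)OC1=O` gives 1.64 ug/mL. Among the compounds with values here, that gap, a 3.3-fold lower number from compound 1 to compound 2 (0.52 log units; beyond the scatter), is the only measured step, and it concerns the double bond, not the chain. Compound 3 `COCCCCCCCCCCC/C=C1\CC(CO)(COC(=O)C(C)(C)C)OC1=O` keeps the double bond of compound 2 and changes the chain: methoxy in place of 4-methoxybutyl on a saturated chain carbon, ten or more bonds along the chain from a double-bonded chain carbon. Within the data shown here, no measured step tests this kind of change, so the direction is a tentative guess and the size of the double-bond step only a rough guide. The expected change is a 1.6-fold higher number from compound 2 to compound 3 (0.21 log units; within the scatter), a modest move towards weaker inhibition. Compound 3 is estimated at 0.8 ug/mL, with an expected range from 0.25 ug/mL to 3 ug/mL.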

Compound 3, concentration for 50% growth inhibition: 2.38 ug/mL
Estimate against measurement, compound 3: 3.0-fold (0.47 log units) below; measured number inside the range.
By their numbers in this assay, from the lowest: compound 2; then compounds 1 and 3 (each within the scatter of the next).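

With the double bond unchanged, methoxy in place of 4-methoxybutyl on a saturated chain carbon gives a 4.8-fold higher number from compound 2 to compound 3 (0.68 log units; beyond the scatter) in this assay. So the far end of the chain matters as well as the double bond, and of these two chains the longer one goes with stronger growth inhibition.

On these data alone, whether a still longer chain, or one ending in a hydroxyl or an amine instead of the methoxy, would inhibit growth more strongly stays open. Nothing measured here points to a cause for this step.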